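A few compounds are considered here, and "the series" means these few. Any claim that something is new, unique, unknown or untested is made for them only; others in the source may bear on it.

Measured so far in a functional assay on SK-MEL-28 cells (Homo sapiens) for cytotoxicity, read by MTT assay; a lower number here means a stronger inhibitor, a higher number a weaker inhibitor: compound 1 `O=S(=O)(NCCCNc1nccc(-c2c(-c3cccc(F)c3)nc3sccn23)n1)c1ccc(F)cc1`, compound 2 `O=S(=O)(NCCNc1nccc(-c2c(-c3cccc(F)c3)nc3sccn23)n1)c1ccc(C(F)(F)F)cc1`, compound 3 `Cc1ccc(S(=O)(=O)NCCCNc2nccc(-c3c(-c4cccc(F)c4)nc4sccn34)n2)cc1`.

Compound 1 reaches only the limit of > 20000 nM in this assay, and that limit is what the limit of > 20000 nM in this assay, at which 1 of the 3 values shown sits, records. Compound 2 gives 8450 nM in this assay. Compound 3 gives 9500 nM in this assay. Compound 3 therefore stands highest of the two numbers, but compound 2 sits within the scatter of it, so no order between the two is claimed; compound 1 adds only a limit.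

Compound 4 `O=S(=O)(NCCNc1nccc(-c2c(-c3cccc(F)c3)nc3sccn23)n1)c1ccccc1` differs from compound 3 by (phenylsulfonyl)amino in place of (((4-methylphenyl)sulfonyl)amino)methyl on a saturated chain carbon, two bonds along the chain from a nitrogen on an aromatic ring. Going by the values given here, one measured step bears on part of this change: an at least 2.1-fold lower number from compound 1 to compound 3 (0.32 log units; beyond the scatter), which shows the methyl group carrying the gain over the fluoro analogue. Among the compounds with values here, for the shorter chain no single-change step exists; compound 2, which carries the shorter chain together with a trifluoromethyl group, and compound 3 show values within the scatter of each other, so the chain length alone gives no sign of a large effect. Removing the methyl is expected to give back part of what an at least 2.1-fold lower number from compound 1 to compound 3 (0.32 log units; beyond the scatter) gained, so a step of a 1.7-fold higher number from compound 3 to compound 4 (0.23 log units; within the scatter) toward a higher number is expected, with a limit read-out not excluded. Compound 4 is estimated at 16000 nM, in the range 6000 nM to 40000 nM.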

Compound 4, half-maximal inhibitory concentration: 19000 nM
Beside the measured number, compound 4's estimate is 1.2-fold (0.07 log units) below it; low and high end bracket the measured number.
By their numbers in this assay, from the lowest: compounds 2, 3 and 4 (each within the scatter of the next, the first and the last beyond it). At a limit, above all of these: compound 1.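

Working notes on the series. In this assay the first one-place read on the group on the aromatic carbon, with the chain of compound 4 held fixed, is that hydrogen in place of trifluoromethyl gives a 2.2-fold higher number from compound 2 to compound 4 (0.35 log units; beyond the scatter) as a modest step, beyond the scatter. The step of a 2.0-fold higher number from compound 3 to compound 4 (0.30 log units; within the scatter) alters the chain and the aromatic substituent at once and stays within the scatter, so it assigns no share to either part. Compound 1 remains a limit of the assay, and the step of an at least 1.0-fold lower number from compound 1 to compound 4 (0.02 log units; that floor lies within the scatter) cannot be read: the limit of > 20000 nM in this assay, at which 1 of the 4 values shown sits.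

No pair shown differs in chain only, so the effect of chain length by itself stays open, as does whether trifluoromethyl keeps its edge over hydrogen on the chain of compound 3. Also open, going by these compounds, is how an amine or a carboxylic acid on that aromatic carbon, or a longer chain between the sulfonamide and the core, would read in this assay.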